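Removing the ring methyl from compound 2 toward compound 3

A few compounds are considered here, and "the series" means these few. Any claim that something is new, unique, unknown or untested is made for them only; others in the source may bear on it.

Compound 1: `CCC(=O)Nc1ccc(-c2nc3cc(C(F)(F)F)ccc3[nH]2)cc1` gives >= 100000 nM in an ADME assay on MT4 cells (Homo sapiens) for cytotoxicity, read by MTT assay, with a stated time of 96 h; on this read-out higher numbers stand for lower toxicity in this test and lower numbers for higher toxicity in this test. Compound 2: `CCN(CC)CC(=O)Nc1ccc(-c2nc3cc(C(F)(F)F)ccc3n2C)cc1` gives 9000 nM.

The value of compound 1 is a limit of this assay, not a number. Among the measured compounds shown here, compound 2 thus holds the only numeric value shown here. Compound 3, `CCN(CC)CC(=O)Nc1ccc(-c2nc3cc(C(F)(F)F)ccc3[nH]2)cc1`, differs from compound 2 by hydrogen in place of methyl on an aromatic nitrogen. For the measured compounds named here, no step between measured compounds connects this change to a shift in this assay, and compound 1 and compound 2 differ in more than this one place. A modest move toward lower toxicity is expected, as a 2.2-fold higher number from compound 2 to compound 3 (0.35 log units; beyond the scatter). Compound 3 is therefore estimated at 20000 nM, between 6000 nM and 100000 nM.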

Compound 3, half-maximal cytotoxic concentration: 8000 nM
The estimate for compound 3 lay 2.5-fold (0.40 log units) above the measured number; measured number inside the range.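

Hydrogen in place of methyl on the aromatic nitrogen gives a 1.1-fold lower number from compound 2 to compound 3 (0.05 log units; within the scatter) in this assay, so this change alone has no effect that can be told from the scatter. The change on the chain does: diethylamino in place of methyl on a saturated chain carbon bound to a carbonyl carbon gives an at least 12-fold lower number from compound 1 to compound 3 (1.09 log units; beyond the scatter). The value of compound 1 is a limit of this assay, and the size of that step rests on it: the limit of >= 100000 nM in this assay, at which 1 of the 3 values shown sits.

Going by these compounds, it remains open whether an ethyl group on the aromatic nitrogen would behave like methyl. On these data alone, it also remains open whether a dimethylamino or pyrrolidine group on the chain would match diethylamino.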